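The source may report more compounds than this note shows. Statements on the series, on what has been measured and on what is new or still open speak of the compounds shown alone.

Measured so far in an assay on isolated protein for inhibition of Indoleamine 2,3-dioxygenase 1 (Homo sapiens), read by spectrophotometry, with a stated time of 1 h; a higher number here means a weaker inhibitor, a lower number a stronger inhibitor:
- compound 1, `O=[N+]([O-])c1ccc(N/C(=N\O)c2ccccc2)c2nonc12`: 268 nM
- compound 2, `O=[N+]([O-])c1ccc(N/C(=N\O)c2ccccc2F)c2nonc12`: 63 nM
- compound 3, `Cc1ccc(/C(=N/O)Nc2ccc([N+](=O)[O-])c3nonc23)cc1`: 204 nM

Compound 3 stands second highest of the three numbers in this assay; its value lies within the scatter of that of compound 1 and is separated from compound 2 by a 3.2-fold higher number from compound 2 to compound 3 (0.51 log units; beyond the scatter). The shared core carries the nitro group and the fused ring system shown in the structures, with variation only on the phenyl attached to the carbon with a double bond to nitrogen.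

Compound 4, `O=[N+]([O-])c1ccc(N/C(=N\O)c2ccc(F)c(Br)c2)c2nonc12`, is not yet measured. It differs from compound 3 by 3-bromo-4-fluorophenyl in place of 4-methylphenyl on a carbon with a double bond to nitrogen.

Going by the values given here, two measured steps bear on this change. The first, a 1.3-fold lower number from compound 1 to compound 3 (0.12 log units; within the scatter), shows that the methyl changes little, so removing it is expected to matter little. Fluoro in place of hydrogen on an aromatic carbon gave a 4.3-fold lower number from compound 1 to compound 2 (0.63 log units; beyond the scatter), a modest step towards stronger inhibition. Among the compounds with values here, no measured step covers bromo on the phenyl. Taken together, compound 4 is expected to give a modestly lower number than compound 3, a step of about a 1.9-fold lower number from compound 3 to compound 4 (0.27 log units; within the scatter), though the halogens here sit at other named positions than the fluoro of compound 2, so the expectation is held loosely.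

Compound 4 is estimated at 110 nM in this assay, with a range of 45 nM to 280 nM.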

Compound 4, half-maximal inhibitory concentration: 92 nM
For compound 4 the middle estimate is 1.2-fold (0.08 log units) above the measured one; measured number inside the range.
By their numbers in this assay, from the lowest: compounds 2 and 4 (each within the scatter of the next); then compounds 3 and 1 (each within the scatter of the next).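

In this assay, 3-bromo-4-fluorophenyl on the carbon with a double bond to nitrogen gives a 2.2-fold lower number from compound 3 to compound 4 (0.35 log units; beyond the scatter) and, against the unsubstituted phenyl, a 2.9-fold lower number from compound 1 to compound 4 (0.46 log units; beyond the scatter) as well, so a phenyl with two halogens also moves the number at this place, and a bromo-bearing ring is compatible with inhibition. The two halogen-bearing rings are not separated, with a 1.5-fold higher number from compound 2 to compound 4 (0.16 log units; within the scatter) leaving 2-fluorophenyl and 3-bromo-4-fluorophenyl level within the scatter. No measurement shown accounts for these steps.

Going by these compounds, the separate contributions of the bromo and the fluoro within 3-bromo-4-fluorophenyl stay open, as the step changes both together. Also open, on these data alone, is how this place responds to a phenyl carrying an amine or a carboxylic acid.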